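This account rests on a few compounds, and the source may have more. Where it says the series, first, only, none or still open, it means among the compounds named here.

Measured compounds:
compound 1 `CC(C)(C)c1ccc(C(=O)N2CCC3(CC2)C(=O)N(CC(=O)N2CCCC(C(N)=O)C2)CN3c2ccccc2)cc1`: 16900 nM
compound 2 `COC(=O)CCNC(=O)CN1CN(c2ccccc2)C2(CCN(C(=O)c3ccc(C4CCCCC4)cc3)CC2)C1=O`: 12900 nM
compound 3 `CCc1nn(CC)c(C2CCN(C(=O)CN3CN(c4ccccc4)C4(CCN(C(=O)c5ccc(C6CCCCC6)cc5)CC4)C3=O)CC2)c1C`: "not determined" (no result reported)

In an assay on HEK293 cells for displacement of a labelled ligand from NPC1-like intracellular cholesterol transporter 1 (Homo sapiens) (a higher number here means a weaker inhibitor, a lower number a stronger inhibitor), compound 1 gives 16900 nM. Compound 2 gives 12900 nM in this assay, and the two numbers lie within the usual scatter of each other, so nothing separates them. Compound 3 has "not determined" (no result reported) in this assay.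

Compound 4 `CCOC(=O)C1CCCN(C(=O)CN2CN(c3ccccc3)C3(CCN(C(=O)c4ccc(C(C)(C)C)cc4)CC3)C2=O)C1` is not yet measured. It differs from compound 1 by ethoxy in place of amino on a carbonyl carbon. Going by the values given here, no step between measured compounds bears on this change, and compound 2, which carries a methyl ester on its own side chain, is within the scatter of compound 1. The expected step in this assay, a 1.1-fold lower number from compound 1 to compound 4 (0.05 log units; within the scatter), is none beyond the scatter. Compound 4 is estimated at 15000 nM in this assay, between 5000 nM and 45000 nM.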

Compound 4, half-maximal inhibitory concentration: 8200 nM
Estimate against measurement, compound 4: 1.8-fold (0.26 log units) above, and the stated range covers the measured number.
By their numbers in this assay, from the lowest: compounds 4, 2 and 1 (each within the scatter of the next, the first and the last beyond it).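

In this assay, going by these compounds alone, the change from 3-carbamoylpiperidin-1-yl to 3-(ethoxycarbonyl)piperidin-1-yl gives a 2.1-fold lower number from compound 1 to compound 4 (0.31 log units; beyond the scatter) as the first one-place comparison. A modest gain in inhibition thus accompanies the replacement of amino, with its hydrogen-bond donor, by ethoxy, which has none. No available measurement accounts for this step.

From the compounds shown here alone, whether the step is specific to ethoxy remains open. A carboxylic acid, a methoxy or a longer alkoxy chain on this carbonyl carbon would test that.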